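Notes on a two-compound series and one untested analogue

The source may hold more compounds than are shown below. What is called first, only, known or untested is meant among the compounds shown, and "the series" means these compounds.

Compound 1 `Nc1cc(N)c2nc(-c3ccccc3)c(Oc3ccc(Cl)c(Cl)c3)nc2c1` was tested in a functional assay on COLO 205 cells (Homo sapiens) for inhibition, read by sulforhodamine B assay, with a stated time of 48 h (on this read-out higher numbers stand for weaker inhibition of growth and lower numbers for stronger inhibition of growth), where compound 1 gives 20400 nM. Compound 2 `CCOC(=O)[C@H](CCC(=O)O)NC(=O)c1ccc(CNc2nc3cc(N)cc(N)c3nc2-c2ccccc2)cc1` in this assay gives 19500 nM. Compound 1 holds the higher of the two numbers, but its gap to compound 2 lies within the scatter, so the two cannot be ordered against each other; both show weak inhibition of growth. Compound 3 `COc1ccc(Sc2nc3cc(N)cc(N)c3nc2-c2ccccc2)cc1` is not yet measured in this assay. It differs from compound 1 in one place: (4-methoxyphenyl)sulfanyl in place of 3,4-dichlorophenoxy on an aromatic carbon. Among the compounds with values here, no step between measured compounds bears on this change, and nothing measured so far separates one substituent at that place from another. The expected step is therefore a 1.3-fold lower number from compound 1 to compound 3 (0.11 log units; within the scatter), with no clear direction and not beyond the scatter. For compound 3 the estimate in this assay is 16000 nM, with a range from 4000 nM to 60000 nM.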

Compound 3, concentration for 50% growth inhibition: 19500 nM
Beside the measured number, compound 3's estimate is 1.2-fold (0.09 log units) below it, within the range that was stated.
By their numbers in this assay, from the lowest: compounds 2, 3 and 1 (each within the scatter of the next).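

In this assay, within the data shown here, (4-methoxyphenyl)sulfanyl in place of 3,4-dichlorophenoxy on the aromatic carbon next to the ring nitrogen gives a 1.0-fold lower number from compound 1 to compound 3 (0.02 log units; within the scatter), the only step read at this position. This place therefore carries two different aryl-bearing groups, one linked through oxygen with two chlorines and the other linked through sulfur with a methoxy, and the numbers do not separate; compound 1 and compound 3 both show weak inhibition of growth. No measurement at hand accounts for this match.

From the compounds shown here alone, since the linking atom and the ring substituents change together in this one step, their separate contributions remain open. Also open, going by these compounds, is whether a tertiary amine or a plain alkyl chain at this place would give a number beyond the scatter.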